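Swapping Trifluoromethyl for Methoxy on the Ester Ring

The source may hold more compounds than are shown below. What is called first, only, known or untested is meant among the compounds shown, and "the series" means these compounds.

Compound 1 `Cc1cc2c(C(C)C)ccc(C)c2cc1OC(=O)c1cccc(C(F)(F)F)c1`: 17.3%
Compound 2 `CC1=CC[C@H](C(C)C)c2cc(C)c(OC(=O)c3cccc(C(F)(F)F)c3)cc21`: 18.3%

Both compounds were tested in a functional assay on SK-LU-1 cells (Homo sapiens) for antiproliferative activity, read by sulforhodamine B assay, with a stated time of 48 h, tested at 50 uM; a higher number here means more inhibition at the concentration tested (going by the name of the read-out), a lower number less inhibition. Compound 1 and compound 2 lie within the scatter of one another, so neither stands apart in this assay. Compound 3 `COc1cccc(C(=O)Oc2cc3c(C)ccc(C(C)C)c3cc2C)c1` has not yet been measured. It differs from compound 1 by methoxy in place of trifluoromethyl on an aromatic carbon. Among the measured compounds shown here, no measured pair shows what such a change does here, so the step is expected to stay within the scatter, and the estimate is a number 2.3 percentage points lower from compound 1 to compound 3 (within the scatter). Compound 3 is therefore expected to give about 15% in this assay, estimated between 4% and 30%.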

Compound 3, a percentage reported as inhibition, at one concentration (the size of the read-out at that concentration, not a potency): 30.6%
The estimate for compound 3 lay 15.6 percentage points below the measured number, outside the stated range (above it).
By their numbers in this assay, from the lowest: compounds 1 and 2 (each within the scatter of the next); then compound 3.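

In this assay, methoxy in place of trifluoromethyl on this aromatic carbon, meta to a large group, gives a number 13.3 percentage points higher from compound 1 to compound 3 (beyond the scatter) on the shared core. This shows that the group at this position can shift the read-out, which compounds 1 and 2 alone could not show, since they differ elsewhere. No available measurement accounts for the rise.

On these data alone, this is a single swap at one position, so the effect of an amine, a hydroxyl group or a longer chain such as ethoxy here remains open. Also open, as far as these compounds go, is whether methoxy would give a similar step on the core of compound 2.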